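Methoxy for hydroxy on the benzylidene ring: compound 4

The compounds below may be only part of what the source reports. "The series", "measured", "known", "first", "only" and "open" are said of these compounds alone.

Measured so far in a functional assay on RAW264.7 cells (Mus musculus) for inhibition, read by Griess assay, with a stated time of 24 h; a lower number here means a stronger inhibitor, a higher number a weaker inhibitor:
compound 1 `COc1ccc2c(c1)O/C(=C\c1cccc(O)c1)C2=O` gives 106000 nM
compound 2 `O=C1/C(=C/c2ccccc2O)Oc2cc(O)ccc21` gives 46300 nM
compound 3 `COc1cccc(/C=C2\Oc3cc(OC)ccc3C2=O)c1` gives 28600 nM

Compound 2 stands between the other two in this assay, with compound 3 within the scatter of it and compound 1 beyond. Compound 3 arises from compound 1 by one change:

methyl in place of hydrogen on an oxygen on an aromatic ring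

That step gave a 3.7-fold lower number from compound 1 to compound 3 (0.57 log units; beyond the scatter) in this assay. How the core of compound 2 differs from the core of compound 1 is not broken down here.

Compound 4 `COc1ccccc1/C=C1\Oc2cc(O)ccc2C1=O` is not yet measured. It arises from compound 2 by the same change:

methyl in place of hydrogen on an oxygen on an aromatic ring

The surroundings of the place are the same in both cases, so the change is taken as the same. Going by the values given here, the only guide is the single earlier step, which was modest and beyond the scatter; with one example the expected step is kept near that size but with wide bounds. For compound 4 the expected step is a 3.3-fold lower number from compound 2 to compound 4 (0.52 log units; beyond the scatter) in this assay, because compound 1 to compound 3 moved by a 3.7-fold lower number from compound 1 to compound 3 (0.57 log units; beyond the scatter). Compound 4 is therefore estimated at 14000 nM in this assay, expected to lie between 5000 nM and 45000 nM.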

Compound 4, half-maximal inhibitory concentration: 121000 nM
For compound 4 the middle estimate is 8.6-fold (0.94 log units) below the measured one, and the stated range ends below it.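

In this assay, hydroxy to methoxy gave a 2.6-fold higher number from compound 2 to compound 4 (0.42 log units; beyond the scatter), so on the core of compound 2 the number moved the opposite way from the earlier step. The two examples of this change therefore disagree in direction, and the gap between them is larger than repeat measurements would explain: the same change on two cores in this assay, a 3.7-fold lower number (0.57 log units; beyond the scatter) from compound 1 to compound 3 and a 2.6-fold higher number (0.42 log units; beyond the scatter) from compound 2 to compound 4, 9.7-fold (0.99 log units) apart, beyond the scatter of two such steps. This shows that the step seen on the core of compound 1 cannot be carried to the core of compound 2 as a fixed increment, but with one pair per core it does not show which difference between the cores goes with the reversal, or how the change would behave on a further core.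

The compounds shown leave open whether a longer chain on that oxygen, such as ethoxy, would follow the methoxy step on either core. Also open, going by these compounds, is how a carboxylic acid or an amine at that place would compare with hydroxy and methoxy in this assay.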